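Trimming the Ester Chain on a Shared Core

A few compounds are considered here, and "the series" means these few. Any claim that something is new, unique, unknown or untested is made for them only; others in the source may bear on it.

Measured so far:
Compound 1, `COC(=O)CCCc1onc(NS(=O)(=O)c2ccc(C(C)(C)C)cc2)c1Sc1cccc(OC)c1`, gives 310 nM in an assay on COS-7 cells for displacement of a labelled ligand from Endothelin receptor type B (Sus scrofa); on this read-out higher numbers stand for weaker inhibition and lower numbers for stronger inhibition.
Compound 2, `Cc1onc(NS(=O)(=O)c2ccc(N)cc2)c1I`, gives only a limit of > 1000000 nM in this assay.

Compound 1 stands alone with an actual number; compound 2 sits at the limit, as the evidence the limit of > 1000000 nM in this assay, at which 1 of the 2 values shown sits, records, and because the two structures differ in several places at once no comparison between them can be drawn from these two values.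

The not yet measured compound 3, `CCc1onc(NS(=O)(=O)c2ccc(C(C)(C)C)cc2)c1Sc1cccc(OC)c1`, differs from compound 1 in one place only: hydrogen in place of (methoxycarbonyl)methyl on a saturated chain carbon, two bonds along the chain from an aromatic carbon. In plainer terms, the chain ending in an ester is cut back to a short alkyl chain, and the rest of the molecule is unchanged.

For the measured compounds named here, no measured pair shows what such a cut does here, so the expectation rests on compound 1 alone. A part of the chain that can accept hydrogen bonds is removed, and a modest weakening is expected rather than a large one. The step of a 2.1-fold higher number from compound 1 to compound 3 (0.32 log units; beyond the scatter) is estimated to be a small loss, possibly within the scatter. For compound 3 the expected value in this assay is 650 nM, between 150 nM and 3000 nM.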

Compound 3, half-maximal inhibitory concentration: 2800 nM
Estimate against measurement, compound 3: 4.3-fold (0.63 log units) below; low and high end bracket the measured number.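

In this assay, cutting 3-(methoxycarbonyl)propyl back to ethyl gives a 9.0-fold higher number from compound 1 to compound 3 (0.96 log units; beyond the scatter) while the rest of the molecule stays the same. For the compounds shown here, this is the first comparison here that changes only one place, and it shows that the chain in this position is not a neutral appendage: shortening it and removing its ester end weakens inhibition by more than the usual scatter between repeat measurements. The data shown give no explanation for this loss.

The compounds shown leave open whether the loss follows from removing the ester group itself or simply from shortening the chain, since both changes happen together in this single step. A longer alkyl chain with no ester, or a chain of similar reach ending in a carboxylic acid or an amine, would help tell these two readings apart and show which kinds of chain end this position tolerates on the shared core.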